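Thiophene for Phenyl at the Para Biaryl Position

The compounds below may be only part of what the source reports. "The series", "measured", "known", "first", "only" and "open" are said of these compounds alone.

Measured compounds:
compound 1, `Cc1ccccc1-n1nc(C)c2c1NC(=O)[C@H](C)S[C@@H]2c1ccc(-c2ccccc2)cc1`, 990 nM;
compound 2, `Cc1nn(-c2ccccc2C(F)(F)F)c2c1C(c1ccc(Oc3ccccc3)cc1)SC(C)C(=O)N2`, 2000 nM.

Two compounds sharing one tricyclic core have been characterised in an assay on isolated protein for agonist activity at Bile acid receptor (Homo sapiens), read by AlphaScreen, with a stated time of 30 min; on this read-out higher numbers stand for an effect only at larger amounts of compound and lower numbers for an effect already at smaller amounts. Compound 1 gives 990 nM, the lower of the two values. For the measured compounds named here, compound 2 gives 2000 nM, a number that lies beyond the usual scatter of this assay relative to compound 1, so the two are distinguishable on the data; the two compounds differ at more than one place, however, and no single step connects them.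

Compound 3, `Cc1ccccc1-n1nc(C)c2c1NC(=O)[C@H](C)S[C@@H]2c1ccc(-c2ccsc2)cc1`, has not yet been measured. It is derived from compound 1 by a single change: thiophen-3-yl in place of phenyl on an aromatic carbon. Going by the values given here, no measured pair shows what this kind of exchange does on this core, so any expectation rests on compound 1 alone. The step from compound 1 to compound 3 in this assay is expected to be small, a 1.1-fold lower number from compound 1 to compound 3 (0.04 log units; within the scatter), with no direction that clearly exceeds the scatter. Compound 3 is therefore estimated to give 900 nM, within a range from 400 nM to 2500 nM.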

Compound 3, half-maximal effective concentration: 1400 nM
For compound 3 the middle estimate is 1.6-fold (0.19 log units) below the measured one; low and high end bracket the measured number.
By their numbers in this assay, from the lowest: compounds 1, 3 and 2 (each within the scatter of the next, the first and the last beyond it).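

In this assay, replacing phenyl with thiophen-3-yl gives a 1.4-fold higher number from compound 1 to compound 3 (0.15 log units; within the scatter), so the two groups cannot be told apart at this place, on an aromatic carbon of a six-membered aromatic ring of carbon only, para to a large group. For the compounds shown here, this is the first single-change comparison on the shared core, and it shows that a five-membered aromatic ring with 1 hetero atom can stand in place of a six-membered aromatic ring of carbon only without a difference this read-out can resolve. Nothing independent of these numbers bears on why the two compounds read alike.

The compounds shown leave open whether any group at this place would carry the number beyond the scatter, for instance a carboxylic acid, an amine or pyridin-3-yl, and so how much freedom the position truly allows. They also leave open whether thiophen-2-yl would read like thiophen-3-yl, and whether the same exchange would behave alike on the core of compound 2, which carries other groups.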